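The compounds below may be only part of what the source reports. "The series", "measured", "known", "first", "only" and "open" are said of these compounds alone.

Measured so far in a functional assay on MCF7 cells (Homo sapiens) for antiproliferative activity, read by MTT assay (a higher number here means a weaker inhibitor, a lower number a stronger inhibitor), as half-maximal inhibitory concentrations:

- compound 1 `NS(=O)(=O)c1cccc(/N=C2\NC(=O)/C(=C3/C(=O)Nc4ccccc43)S2)c1` gives > 200000 nM
- compound 2 `NS(=O)(=O)c1ccc(/N=C2\NC(=O)/C(=C3/C(=O)Nc4ccc(Br)cc43)S2)cc1` gives 11300 nM

The entry for compound 1 is a limit of the assay and not a number. For the measured compounds named here, compound 2 provides the only actual number, 11300 nM, so it is the sole numerical anchor for what follows.

The next compound is compound 3 `Cc1ccc2c(c1)/C(=C1/S/C(=N/c3ccc(S(N)(=O)=O)cc3)NC1=O)C(=O)N2`, which differs from compound 2 by one substitution: methyl in place of bromo on an aromatic carbon. In words, this is methyl in place of bromo on an aromatic carbon, and everything else stays the same. Going by the values given here, no measured pair isolates a change at this carbon, so the expectation has no direct precedent and rests only on compound 2 at 11300 nM. A small shift toward weaker inhibition in this assay is expected, and a result within the usual scatter would be no surprise. The expected size of the step is a 1.3-fold higher number from compound 2 to compound 3 (0.12 log units; within the scatter). For compound 3 the estimate is 15000 nM, with an expected range from 6000 nM to 40000 nM.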

Compound 3, half-maximal inhibitory concentration: > 200000 nM
Compound 3: a limit, no number (the forecaster's own chance of this, stated with the estimate: 8%); at least 13-fold (1.12 log units) between middle value and limit.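

This carbon is not indifferent in this assay: methyl in place of bromo, one heavy atom for one heavy atom with no change in the count of hydrogen-bond donors or acceptors, gives an at least 17-fold higher number from compound 2 to compound 3 (1.24 log units; beyond the scatter). Compound 3 gives > 200000 nM, which is a limit of the assay and not a number, so the step sets only a lower bound on the change and its true size cannot be read: the limit of > 200000 nM in this assay, at which 2 of the 3 values shown sit. Among the compounds shown, bromo is the only group at this carbon that goes with a number, which makes this aromatic carbon the first place in the series where a single change is seen to matter.

Compound 1 differs from compound 2 in more than one place, so it cannot separate the contribution of bromo from that of the rest of the structure. Going by these compounds, whether chloro, methoxy or an amine on this carbon would keep a number in this assay, and whether bromo is special or methyl alone is poorly tolerated, stays open.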